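Cyclohexyl for 3-(dimethylamino)propyl on the ring amine

A few compounds are considered here, and "the series" means these few. Any claim that something is new, unique, unknown or untested is made for them only; others in the source may bear on it.

Compound 1 `Cc1cccc2sc(NC(=O)CCN3CCN(C(C)(C)C)CC3)nc12` gives 200 nM in an assay on membranes from liver for displacement of a labelled ligand from Sigma intracellular receptor 2 (Rattus norvegicus), read by scintillation counting, with a stated time of 120 min; on this read-out lower numbers stand for stronger inhibition and higher numbers for weaker inhibition. Compound 2 `Cc1cccc2sc(NC(=O)CCN3CCN(CCN(C)C)CC3)nc12` reaches only a limit of this assay, > 1000 nM. Compound 3 `Cc1cccc2sc(NC(=O)CCN3CCN(CCCN(C)C)CC3)nc12` likewise reaches only a limit, > 1000 nM. The shift is an at least 5.0-fold higher number from compound 1 to compound 2 (0.69 log units; beyond the scatter) and an at least 5.0-fold higher number from compound 1 to compound 3 (0.69 log units; beyond the scatter), whereas the comparison a step that the two limits leave unreadable from compound 2 to compound 3 remains unresolved. Compound 3 therefore stands at the weak end of the numbers shown, on (the limit of > 1000 nM in this assay, at which 2 of the 3 values shown sit), and no number separates it from compound 2.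

Compound 4 `Cc1cccc2sc(NC(=O)CCN3CCN(C4CCCCC4)CC3)nc12` carries the change (cyclohexyl in place of 3-(dimethylamino)propyl on an amine nitrogen in a ring). Going by the values given here, the steps that bear on it are those from compound 1, in which the entry of a dimethylamino-bearing chain in place of tert-butyl cost potency beyond the scatter; the new group, like tert-butyl, has no hydrogen-bond acceptor. The step from compound 3 to compound 4 is expected to reverse that loss, giving a lower number in this assay, by about an at least 3.3-fold lower number from compound 3 to compound 4 (0.52 log units; beyond the scatter). Compound 4 is accordingly expected to give about 300 nM, within 100 nM to 1000 nM.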

Compound 4, inhibition constant: 233 nM
Estimate against measurement, compound 4: 1.3-fold (0.11 log units) above; low and high end bracket the measured number.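

In this assay, cyclohexyl and tert-butyl on the ring amine nitrogen cannot be told apart, with a 1.2-fold higher number from compound 1 to compound 4 (0.07 log units; within the scatter). The same cyclohexyl group in place of the dimethylamino-bearing chains gives an at least 4.2-fold lower number from compound 3 to compound 4 (0.63 log units; beyond the scatter) and an at least 4.2-fold lower number from compound 2 to compound 4 (0.63 log units; beyond the scatter); because 3-(dimethylamino)propyl and cyclohexyl have the same heavy-atom count, that count alone does not separate the weak from the stronger compounds here. Compound 2 and compound 3 remain limits of the assay rather than numbers, so the full size of both steps stays unread: the limit of > 1000 nM in this assay, at which 2 of the 4 values shown sit.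

On these data alone, whether the loss follows the chain itself or its dimethylamino end stays open. Also open, as far as these compounds go, is how a plain pentyl chain or a phenyl ring on this nitrogen would compare with cyclohexyl and tert-butyl.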